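Tetrazole-bearing chain end exchanged for a dimethylcarbamoylmethyl end

This account rests on a few compounds, and the source may have more. Where it says the series, first, only, none or still open, it means among the compounds named here.

Compound 3 `CCc1cc(C(C)=O)c(O)cc1OCCCCCC(C)(C)c1nnn(C)n1` holds the highest of the three numbers in an assay on isolated protein for inhibition of leukotriene B4 receptor 1 (Homo sapiens), tested at 10 uM (on this read-out lower numbers stand for less inhibition and higher numbers for more inhibition at the one concentration tested (going by the name of the read-out)), giving 95%; compound 1 `CCc1cc(C(C)=O)c(O)cc1OCCCCC#N` gives 92% and compound 2 `CCc1cc(C(C)=O)c(O)cc1OCCCC(C)(C)C#N` gives 85%, both within the scatter of compound 3. Compound 4 `CCc1cc(C(C)=O)c(O)cc1OCCCCCCC(=O)N(C)C` carries (dimethylcarbamoyl)methyl in place of 1-methyl-1-(2-methyl-2H-tetrazol-5-yl)ethyl on a saturated chain carbon, five bonds along the chain from an oxygen on an aromatic ring. Among the measured compounds shown here, the one measured step, a number 7 percentage points lower from compound 1 to compound 2 (within the scatter), also alters the group on a saturated chain carbon, three bonds along the chain from an oxygen on an aromatic ring, and stays within the scatter. For the measured compounds named here, no measured step exchanges a 1-methyl-1-(2-methyl-2H-tetrazol-5-yl)ethyl group for a (dimethylcarbamoyl)methyl group, so the bearing is loose. A small downward step is expected, a number 15 percentage points lower from compound 3 to compound 4 (beyond the scatter). Compound 4 is estimated at 80%, in the range 60% to 95%.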

Compound 4, a percentage reported as inhibition, at one concentration (the size of the read-out at that concentration, not a potency): 100%
Beside the measured number, compound 4's estimate is 20 percentage points below it; measured number above the stated range.
By their numbers in this assay, from the lowest: compounds 2, 1, 3 and 4 (each within the scatter of the next, the first and the last beyond it).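

In this assay, the (dimethylcarbamoyl)methyl group takes the place of the 1-methyl-1-(2-methyl-2H-tetrazol-5-yl)ethyl group with no loss outside the scatter (a number 5 percentage points higher from compound 3 to compound 4 (within the scatter)), so the five-membered aromatic ring is not required at this position to keep the number high. Against the nitrile-ended chains, the same amide end gives two different readings (a number 8 percentage points higher from compound 1 to compound 4 (within the scatter); a number 15 percentage points higher from compound 2 to compound 4 (beyond the scatter)), and only the second lies beyond the scatter. No evidence on hand bears on the cause of these steps.

As far as these compounds go, whether a carboxylic acid or a primary amide at the chain end would hold the number in this assay stays open. So does the effect of a shorter chain carrying the dimethylcarbamoyl end.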